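A Heteroaryl Swap on a Weakly Cytotoxic Scaffold

The source may report more compounds than this note shows. Statements on the series, on what has been measured and on what is new or still open speak of the compounds shown alone.

Measured compounds:
Compound 1 `O=C(N/N=C/C1=Cc2ccccc2OC1)c1ccc(Cl)cc1` — in a toxicity assay on HEK-293T cells (Homo sapiens) for cytotoxicity, read by MTT assay, with a stated time of 72 h (on this read-out lower numbers stand for stronger inhibition and higher numbers for weaker inhibition), compound 1 gives "not determined" (no result reported).
Compound 2 `CC1Oc2ccccc2C=C1/C=N/NC(=O)c1ccc(Cl)cc1` — in this assay compound 2 gives "not determined" (no result reported).
Compound 3 `O=C(N/N=C/C1=Cc2ccccc2OC1c1ccccc1)c1ccc(Cl)cc1` — in this assay compound 3 gives 13200 nM.

Going by the values given here, compound 3 is the only member of this set with a number to its name: in this assay compound 3 gives 13200 nM, a weak effect on cell viability. Among the compounds with values here, compound 1 and compound 2 share the core of compound 3 but were not characterised in this assay, so they offer no comparison, and no step between two measured compounds is available to show how any structural change moves this read-out.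

Compound 4 `Cc1nnsc1C(=O)N/N=C/C1=Cc2ccccc2OC1c1ccccc1` is the next compound to be tested. It differs from compound 3 in one place: 4-methyl-1,2,3-thiadiazol-5-yl in place of 4-chlorophenyl on a carbonyl carbon. Within the data shown here, the measured data hold no step that bears on this change. The core on which it sits is left untouched. Among the measured compounds shown here, with a single reference value and no measured step to lean on, the most defensible expectation is that the step of a 1.1-fold higher number from compound 3 to compound 4 (0.06 log units; within the scatter) stays within the usual scatter of repeated measurements. Compound 4 is therefore expected to give about 15000 nM in this assay, with a plausible range from 5000 nM to 50000 nM.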

Compound 4, half-maximal inhibitory concentration: 30200 nM
Compound 4: the middle estimate sits 2.0-fold (0.30 log units) below what was measured; measured number inside the range.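

Going by these compounds alone, the swap gives the first measured step in this set and shows that the group on the carbonyl carbon is not a silent position in this assay: replacing 4-chlorophenyl with 4-methyl-1,2,3-thiadiazol-5-yl brings a 2.3-fold higher number from compound 3 to compound 4 (0.36 log units; beyond the scatter), a modest move towards weaker inhibition that lies beyond the usual scatter. With the core left untouched, a six-membered aromatic ring of carbon only and a five-membered aromatic ring with 3 hetero atoms are therefore not interchangeable on this read-out, although the size of the difference is small. Nothing at hand explains why the number rises, so the step stands as an observation without a cause.

This single step cannot show whether the higher number follows the change of ring or the methyl group that the new ring carries, and a thiadiazole without that methyl group would help separate the two. It also leaves open how the read-out would respond to a group of a different kind on the carbonyl carbon, such as an aminophenyl ring or a benzoic acid.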